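A few compounds are considered here, and "the series" means these few. Any claim that something is new, unique, unknown or untested is made for them only; others in the source may bear on it.

Measured compounds:
- compound 1, `CCC(=O)N(Cc1ccc(OC)c(O)c1)c1cc(OC)c(OC)c(OC)c1`: 50 nM
- compound 2, `C/C=C/C(=O)N(Cc1ccc(OC)c(C)c1)c1cc(OC)c(OC)c(OC)c1`: 14500 nM

Both were tested in a functional assay on MGC-803 cells (Homo sapiens) for inhibition, read by MTT assay, with a stated time of 48 h; on this read-out lower numbers stand for stronger inhibition and higher numbers for weaker inhibition. Compound 1 gives the lower of the two numbers, and compound 2 sits far above it, a gap well beyond the usual scatter of repeated measurements. Since compound 2 differs from compound 1 in more than one place, nothing can be read from that gap about any single change.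

Compound 3, `COc1ccc(CN(C(=O)C2CC2)c2cc(OC)c(OC)c(OC)c2)cc1O`, has not yet been tested. It differs from compound 1 in one place: cyclopropyl in place of ethyl on a carbonyl carbon. The core and the rest of the molecule are unchanged. Within the data shown here, no measured pair shows this change on its own, so the size of the step is unknown. In the absence of such a comparison, the step from compound 1 to compound 3 is expected to be small, likely within the scatter: a 1.2-fold higher number from compound 1 to compound 3 (0.08 log units; within the scatter). For compound 3 the expected value in this assay is 60 nM, with a range from 20 nM to 200 nM.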

Compound 3, half-maximal inhibitory concentration: 59 nM
The estimate for compound 3 lay 1.0-fold (0.01 log units) above the measured number, within the range that was stated.
By their numbers in this assay, from the lowest: compounds 1 and 3 (each within the scatter of the next); then compound 2.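

Putting cyclopropyl in place of ethyl on a carbonyl carbon, whose other neighbour is an amide-type nitrogen, gives in this assay a 1.2-fold higher number from compound 1 to compound 3 (0.07 log units; within the scatter) and so leaves the two compounds indistinguishable on this read-out. Among these compounds, this is the first single change that can be read at this position, and it shows that the 3 heavy atoms and the three-membered ring of cyclopropyl can stand in place of the 2 heavy atoms of ethyl without a measurable step in this one pair. Nothing on hand explains this result.

Going by these compounds, it remains open whether a longer chain such as butyl, a larger ring such as cyclohexyl, or a group carrying an amine or a carboxylic acid on the same carbonyl carbon would also stay close to compound 1. The steps to compound 2 cannot be read, as it differs from the other compounds in more than one place.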